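Amine substituent series: from cyclopentylamino to piperidin-1-yl

The source may hold more compounds than are shown below. What is called first, only, known or untested is meant among the compounds shown, and "the series" means these compounds.

Compound 2 `O=C1C=C(NC2CCCC2)C(=O)c2c1nc1n2[C@H]2OC[C@@H](O)[C@H]2OC1` gives in a functional assay on HeLa cells (Homo sapiens) for inhibition, read by sulforhodamine B assay (a lower number here means a stronger inhibitor, a higher number a weaker inhibitor), only > 16000 nM, which is a limit of the assay rather than a number. It therefore sits at the limit of > 16000 nM in this assay, at which 1 of the 3 values shown sits, the weakest reading among the three measured compounds. Compound 1 `CCCc1ccc(NC2=CC(=O)c3nc4n(c3C2=O)[C@H]2OC[C@@H](O)[C@H]2OC4)cc1` gives 4990 nM, and compound 3 `CCOc1ccccc1NC1=CC(=O)c2nc3n(c2C1=O)[C@H]1OC[C@@H](O)[C@H]1OC3` gives 6040 nM; the two aryl amines differ by a 1.2-fold higher number from compound 1 to compound 3 (0.08 log units; within the scatter), while the cyclopentyl amine drops out by an at least 3.2-fold higher number from compound 1 to compound 2 (0.50 log units; beyond the scatter) and by an at least 2.6-fold lower number from compound 2 to compound 3 (0.42 log units; beyond the scatter).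

Compound 4 `O=C1C=C(N2CCCCC2)C(=O)c2c1nc1n2[C@H]2OC[C@@H](O)[C@H]2OC1` is the next member, carrying (piperidin-1-yl in place of cyclopentylamino on a double-bonded ring carbon). Both measured steps that touch compound 2 concern the same amine position, and both show the cyclopentyl compound at the limit while the aryl compounds give numbers. For the measured compounds named here, no measured step covers a tertiary amine at this position, so the expectation rests only on compound 2 itself. Compound 4 is expected to remain at or beyond the limit, with a step that the limit leaves unreadable from compound 2 to compound 4 estimated. Compound 4 is estimated at 20000 nM, with a range from 8000 nM to 60000 nM.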

Compound 4, half-maximal inhibitory concentration: > 16000 nM
Compound 4: only a limit was reported; the forecaster's own chance of this, stated with the estimate: 70%; the middle value lies beyond the limit too.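

In this assay compound 4 gives > 16000 nM, a limit of the assay. For the compounds shown here, compound 2 gives > 16000 nM, also a limit, so no step between compound 2 and compound 4 can be read. Going by these compounds, how piperidin-1-yl and cyclopentylamino compare in this assay stays open.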